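This account rests on a few compounds, and the source may have more. Where it says the series, first, only, none or still open, it means among the compounds named here.

Measured in a functional assay on ES2 cells (Homo sapiens) for inhibition, read by MTT assay, with a stated time of 48 h; on this read-out lower numbers stand for stronger inhibition and higher numbers for weaker inhibition:
- compound 1 `O=C(CCCOc1no[n+]([O-])c1S(=O)(=O)c1ccccc1)NO`: 3780 nM
- compound 2 `O=C(CCCCOc1no[n+]([O-])c1S(=O)(=O)c1ccccc1)NO`: 2530 nM
- compound 3 `O=C(COCCOc1no[n+]([O-])c1S(=O)(=O)c1ccccc1)NO`: 8690 nM

Compound 3 has the highest number of the three. Compound 4 `O=C(/C=C/COc1no[n+]([O-])c1S(=O)(=O)c1ccccc1)NO` differs from it by 2-(hydroxycarbamoyl)ethenyl in place of ((hydroxycarbamoyl)methoxy)methyl on a saturated chain carbon bound to an oxygen on an aromatic ring. Two modest measured steps bear on this, a 2.3-fold higher number from compound 1 to compound 3 (0.36 log units; beyond the scatter) and a 3.4-fold higher number from compound 2 to compound 3 (0.54 log units; beyond the scatter). Each brings in the (hydroxycarbamoyl)methoxy group that compound 4 lacks. Without that group the numbers stay within the scatter, a 1.5-fold lower number from compound 1 to compound 2 (0.17 log units; within the scatter). Within the data shown here, no measured compound carries the new double bond, so uncertainty remains. A modest drop is therefore expected in this assay, an estimated 2.2-fold lower number from compound 3 to compound 4 (0.34 log units; beyond the scatter). Compound 4 is expected at 4000 nM, within an estimated range of 1600 nM to 10000 nM.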

Compound 4, half-maximal inhibitory concentration: 19100 nM
Beside the measured number, compound 4's estimate is 4.8-fold (0.68 log units) below it; the whole stated range lies below it.
By their numbers in this assay, from the lowest: compounds 2 and 1 (each within the scatter of the next); then compound 3; then compound 4.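

In this assay, the step that isolates the double bond, a 5.1-fold higher number from compound 1 to compound 4 (0.70 log units; beyond the scatter), shows that 2-(hydroxycarbamoyl)ethenyl in place of 2-(hydroxycarbamoyl)ethyl raises the number without any (hydroxycarbamoyl)methoxy group present. Compound 4 also stands highest of the four, with a 2.2-fold higher number from compound 3 to compound 4 (0.34 log units; beyond the scatter) and a 7.5-fold higher number from compound 2 to compound 4 (0.88 log units; beyond the scatter), so a chain on this saturated carbon need not carry that ether oxygen to read weaker. Nothing available explains this rise. Going by these compounds, whether a longer chain bearing the same double bond, or a carboxylic acid in place of the hydroxycarbamoyl end, would follow this trend remains open.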